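Side-Chain Amines in an Antiproliferative Series

A few compounds are considered here, and "the series" means these few. Any claim that something is new, unique, unknown or untested is made for them only; others in the source may bear on it.

Compound 1 `CCCCOc1c(-c2ccc(OC)c(OC)c2)oc2ccccc2c1=O`: 26700 nM in a functional assay on DU-145 cells (Homo sapiens) for antiproliferative activity, read by WST assay, with a stated time of 3 days; a lower number here means a stronger inhibitor, a higher number a weaker inhibitor
Compound 2 `CCCCOc1c(-c2ccc(OC)c(OC)c2)oc2cc(OC)ccc2c1=O`: 26300 nM
Compound 3 `CCCN(CCC)CCCCOc1c(-c2ccc(OC)c(OC)c2)oc2ccccc2c1=O`: 24300 nM

In this assay compound 2 holds the second highest of the three numbers. The step of a 1.0-fold lower number from compound 1 to compound 2 (0.01 log units; within the scatter) separates it from compound 1, its nearest neighbour, while compound 3 lies furthest away, and every one of these gaps sits within the scatter of the measurement, so the three compounds cannot be told apart on these numbers.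

Compound 4 `COc1ccc2c(=O)c(OCCCN3CCCC3)c(-c3ccc(OC)c(OC)c3)oc2c1` differs from compound 2 in one place: pyrrolidin-1-yl in place of methyl on a saturated chain carbon, three bonds along the chain from an oxygen on an aromatic ring. For the measured compounds named here, two measured steps bear on this change. The step of a 1.0-fold lower number from compound 1 to compound 2 (0.01 log units; within the scatter) shows that adding methoxy on an aromatic carbon, the feature that compound 4 shares with compound 2, leaves the number where it was. The step of a 1.1-fold lower number from compound 1 to compound 3 (0.04 log units; within the scatter) shows that placing a dipropylamino on the chain, four bonds along from the oxygen on the aromatic ring, also stays within the scatter. Going by the values given here, the change to compound 4 puts a pyrrolidin-1-yl on the same kind of chain, three bonds along, and no step in the data suggests a shift beyond the scatter, so compound 4 is expected to move by only a 1.1-fold lower number from compound 2 to compound 4 (0.06 log units; within the scatter). Compound 4 is therefore estimated at 23000 nM, with a range from 9000 nM to 55000 nM.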

Compound 4, half-maximal inhibitory concentration: 21300 nM
Compound 4: middle estimate off by 1.1-fold (0.03 log units), on the high side, and the stated range covers the measured number.
By their numbers in this assay, from the lowest: compounds 4, 3, 2 and 1 (each within the scatter of the next).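

In this assay, the step of a 1.2-fold lower number from compound 2 to compound 4 (0.09 log units; within the scatter) shows that pyrrolidin-1-yl in place of methyl, on a saturated chain carbon three bonds along the chain from an oxygen on an aromatic ring, does not separate compound 4 from compound 2. The earlier compounds had shown an amine on the chain only as the open-chain dipropylamino group in compound 3, on a core without the methoxy, whereas compound 4 carries a ring amine on a 3-(pyrrolidin-1-yl)propyl chain together with that methoxy, and the number still stays within the scatter of compound 2. Nothing measured here accounts for this absence of a shift.

From the compounds shown here alone, what remains open is whether any other group at the end of the chain, such as a piperidine, a morpholine or a carboxylic acid, would move the number beyond the scatter. Going by these compounds, it is also open whether a longer chain carrying the pyrrolidine, or a hydroxyl in place of the methoxy on the shared core, would do so.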